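Swapping one halogen on the terminal phenyl urea

This account rests on a few compounds, and the source may have more. Where it says the series, first, only, none or still open, it means among the compounds named here.

Compound 1, `O=C(Nc1cccc(CNc2nccnc2Cl)c1)Nc1ccccc1Cl`: 6680 nM
Compound 2, `CCOc1ccc(NC(=O)Nc2cccc(CNc3nccnc3Cl)c2)cc1`: 9080 nM
Compound 3, `Cc1ccc(NC(=O)Nc2cccc(CNc3nccnc3Cl)c2)cc1Cl`: 7390 nM

All three compounds share a core and were tested in a functional assay on T-24 cells (Homo sapiens) for antiproliferative activity, read by MTT assay, with a stated time of 48 h; on this read-out lower numbers stand for stronger inhibition and higher numbers for weaker inhibition. Compound 1 gives the lowest number of the three, but its steps to the others are small: a 1.4-fold higher number from compound 1 to compound 2 (0.13 log units; within the scatter) and a 1.1-fold higher number from compound 1 to compound 3 (0.04 log units; within the scatter), both within the scatter, so no ranking among them can be claimed. The step from compound 2 to compound 3, a 1.2-fold lower number from compound 2 to compound 3 (0.09 log units; within the scatter), is likewise within the scatter.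

Compound 4, `O=C(Nc1cccc(CNc2nccnc2Cl)c1)Nc1ccccc1F`, differs from compound 1 in one place: fluoro in place of chloro on an aromatic carbon. Going by the values given here, no measured pair shows a chloro-to-fluoro exchange, so no step bears directly on it. What the data do show is that changing the whole 2-chlorophenyl group to quite different groups, as in compound 2 and compound 3, moved the number only within the scatter. A 2-fluorophenyl in place of 2-chlorophenyl is a smaller change, so no step beyond the scatter is expected in this assay. Compound 4 is therefore estimated at 7500 nM, with a range of 3500 nM to 16000 nM, meaning an expected step of a 1.1-fold higher number from compound 1 to compound 4 (0.05 log units; within the scatter).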

Compound 4, half-maximal inhibitory concentration: 7450 nM
Estimate against measurement, compound 4: 1.0-fold (0.00 log units) above, within the range that was stated.
By their numbers in this assay, from the lowest: compounds 1, 3, 4 and 2 (each within the scatter of the next).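

In this assay, chloro gives way to fluoro on an aromatic carbon ortho to a large group, and the result is a 1.1-fold higher number from compound 1 to compound 4 (0.05 log units; within the scatter), so the first direct test of this halogen exchange shows no change that can be told from the scatter. Compound 4 also stays within the scatter of the compounds carrying other groups, with a 1.0-fold higher number from compound 3 to compound 4 (0.00 log units; within the scatter) and a 1.2-fold lower number from compound 2 to compound 4 (0.09 log units; within the scatter), so all four terminal groups shown give numbers that cannot be ranked. No measurement shown here gives a reason for this lack of separation.

On these data alone, it remains open whether any group on this phenyl ring can move the number beyond the scatter. An amine, a carboxylic acid or a longer chain such as butoxy on this ring would put that question to a sharper test.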